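A few compounds are considered here, and "the series" means these few. Any claim that something is new, unique, unknown or untested is made for them only; others in the source may bear on it.

Measured in a functional assay on EBC-1 cells (Homo sapiens) for antiproliferative activity, with a stated time of 72 h; on this read-out higher numbers stand for weaker inhibition and lower numbers for stronger inhibition:
- compound 1 `Fc1cc(-c2ccsc2)cn2c(Cc3ccc4ncccc4c3)cnc12` gives 444 nM
- compound 2 `N#Cc1ccc(-c2cc(F)c3ncc(Cc4ccc5ncccc5c4)n3c2)cc1F` gives 145 nM
- compound 3 `COc1ccc(-c2cc(F)c3ncc(Cc4ccc5ncccc5c4)n3c2)cc1F` gives 407 nM

Compound 3 stands in the upper part of these three numbers, level with compound 1 (a 1.1-fold lower number from compound 1 to compound 3 (0.04 log units; within the scatter)) and apart from compound 2 (a 2.8-fold higher number from compound 2 to compound 3 (0.45 log units; beyond the scatter)). The change to compound 4 `CCO/N=C(\C)c1cc(F)c2ncc(Cc3ccc4ncccc4c3)n2c1` is a group of 6 heavy atoms (4 carbon, 1 nitrogen, 1 oxygen; no ring) in place of a group of 9 heavy atoms (7 carbon, 1 oxygen, 1 fluorine; one six-membered aromatic ring of carbon only), on an aromatic carbon, meta to a fluoro group. The other swap at this carbon gave a 3.1-fold lower number from compound 1 to compound 2 (0.49 log units; beyond the scatter), so the steps there are modest or within the scatter. For the measured compounds named here, each of them keeps an aromatic ring at this carbon, and no measured compound shows a group with no ring there. No step beyond the scatter is therefore expected in this assay, though with wide uncertainty. The expected step is a 1.4-fold lower number from compound 3 to compound 4 (0.13 log units; within the scatter). For compound 4 the estimated value is 300 nM, with an expected range of 70 nM to 1300 nM.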

Compound 4, half-maximal inhibitory concentration: 1480 nM
Compound 4: the middle estimate sits 4.9-fold (0.69 log units) below what was measured; the whole stated range lies below it.
By their numbers in this assay, from the lowest: compound 2; then compounds 3 and 1 (each within the scatter of the next); then compound 4.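

At this aromatic carbon, the group with no ring in compound 4 gives a higher number in this assay than each ring-bearing group, and all three steps lie beyond the scatter (a 3.6-fold higher number from compound 3 to compound 4 (0.56 log units; beyond the scatter); a 3.3-fold higher number from compound 1 to compound 4 (0.52 log units; beyond the scatter); a 10-fold higher number from compound 2 to compound 4 (1.01 log units; beyond the scatter)). The position therefore responds to more than swaps among aromatic rings, although one ring-free group cannot separate loss of the ring from the identity of this chain. Nothing at hand accounts for the rise.

From the compounds shown here alone, whether an amine, a carboxylic acid or a longer chain at this carbon behaves like the group in compound 4 remains open. So does whether a saturated ring such as piperidine matches the aromatic rings.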